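The compounds below may be only part of what the source reports. "The series", "measured", "known", "first", "only" and "open" are said of these compounds alone.

Measured so far:
Compound 1, `Cc1cc(NC(=O)c2ccc(C#N)cc2)ccc1NS(C)(=O)=O`, gives 43500 nM in an ADME assay on HEK293 cells (Homo sapiens) for cytotoxicity, read by MTT assay, with a stated time of 48 h; a lower number here means a stronger inhibitor, a higher number a weaker inhibitor.
Compound 2, `CCS(=O)(=O)Nc1ccc(NC(=O)c2ccc(C#N)cc2)cc1C`, reaches only a limit of this assay, > 250000 nM.
Compound 3, `Cc1cc(NC(=O)c2ccc(Cl)cc2)ccc1NS(=O)(=O)C(F)(F)F`, gives 201000 nM.

Compound 3 has the highest of the two numbers shown, so it is the weaker of the two in this assay; compound 1 sits lower by a clear margin, and compound 2 contributes a limit rather than a number. Compound 4 is `Cc1cc(NC(=O)c2ccc(C#N)cc2)ccc1NS(=O)(=O)C(F)(F)F`, not yet measured. It differs from compound 3 in one place: cyano in place of chloro on an aromatic carbon.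

Going by the values given here, the only measured step is an at least 5.7-fold higher number from compound 1 to compound 2 (0.75 log units; beyond the scatter), which concerns the chain on the sulfonyl sulfur and says nothing directly about the cyano-for-chloro exchange on the benzoyl ring. Compound 1 and compound 3 differ in two places at once, so their gap cannot be assigned to this exchange alone. Among the compounds with values here, with no step that bears on it, the expectation for compound 4 is a change of a 1.3-fold lower number from compound 3 to compound 4 (0.10 log units; within the scatter) relative to compound 3, that is, none beyond the scatter, with a wide range to allow for either direction. The estimate for compound 4 in this assay is 160000 nM, between 60000 nM and 250000 nM.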

Compound 4, half-maximal inhibitory concentration: > 250000 nM
Compound 4: a limit, no number; the forecaster's own chance of this, stated with the estimate: 30%; middle value at least 1.5-fold (0.19 log units) from the limit.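

In this assay, cyano in place of chloro on this aromatic carbon gives an at least 1.2-fold higher number from compound 3 to compound 4 (0.09 log units; that floor lies within the scatter), so that floor does not establish a real change, though the cyano compound shows no stronger inhibition than its chloro partner. Going by these compounds alone, with the 4-cyanophenyl part held constant, trifluoromethyl in place of methyl on the sulfonyl sulfur gives an at least 5.7-fold higher number from compound 1 to compound 4 (0.75 log units; beyond the scatter), a floor beyond the scatter that matches the one for the ethyl change, an at least 5.7-fold higher number from compound 1 to compound 2 (0.75 log units; beyond the scatter), so both larger groups on the sulfur weaken inhibition relative to methyl. Compound 4 gives only a limit, > 250000 nM, so the full size of its steps stays hidden: the limit of > 250000 nM in this assay, at which 2 of the 4 values shown sit.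

Compound 2 and compound 4 both stand at limits, so the step between them cannot be read, and the compounds shown cannot rank ethyl against trifluoromethyl. Also open, as far as these compounds go, is how an amine or a carboxylic acid on the same aromatic carbon would compare with chloro and cyano, and whether a longer chain on the sulfonyl sulfur would keep the number this high.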